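The source may report more compounds than this note shows. Statements on the series, on what has been measured and on what is new or still open speak of the compounds shown alone.

Measured so far in a functional assay on CCRF-CEM cells (Homo sapiens) for antiproliferative activity, read by MTT assay, with a stated time of 48 h, tested at 12.5 uM; on this read-out higher numbers stand for a weaker effect at the one concentration tested and lower numbers for a stronger effect:
compound 1, `OC(CCn1nc2c(Br)c(Br)c(Br)c(Br)c2n1)c1ccc(Br)cc1`, 89%
compound 2, `OC(CCn1nc2c(Br)c(Br)c(Br)c(Br)c2n1)c1cccc(Cl)c1`, 70%

Compound 2 stands lowest of the two numbers in this assay, the nearest being compound 1, which reads higher by a number 19 percentage points lower from compound 1 to compound 2 (beyond the scatter). That one step, 3-chlorophenyl in place of 4-bromophenyl on a saturated chain carbon bound to an oxygen on a saturated carbon and a saturated chain carbon, is the only one measured.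

Compound 3, `OC(CCn1nc2c(Br)c(Br)c(Br)c(Br)c2n1)c1ccc(Cl)cc1`, has not yet been run in this assay. It differs from compound 2 by 4-chlorophenyl in place of 3-chlorophenyl on a saturated chain carbon bound to an oxygen on a saturated carbon and a saturated chain carbon. The step from compound 1 to compound 2 bears on this only in part, since it changes both halogen and its place at once; it is modest in size and beyond the scatter. The expected direction for compound 3 is therefore a step back toward the number of compound 1, estimated as a number 10 percentage points higher from compound 2 to compound 3 (within the scatter), but with wide uncertainty. Compound 3 is expected to give 80% in this assay, within a range of 64% to 96%.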

Compound 3, a percentage reported as activity, at one concentration (the size of the read-out at that concentration, not a potency): 93%
Beside the measured number, compound 3's estimate is 13 percentage points below it; the range from low to high includes it.
By their numbers in this assay, from the lowest: compound 2; then compounds 1 and 3 (each within the scatter of the next).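

In this assay, moving the chlorine alone gives a number 23 percentage points higher from compound 2 to compound 3 (beyond the scatter), so on the saturated chain carbon bound to an oxygen, 3-chlorophenyl and 4-chlorophenyl are not interchangeable. Changing the halogen alone gives a number 4 percentage points higher from compound 1 to compound 3 (within the scatter), a step that does not separate chloro from bromo on an aromatic carbon. Across these three compounds, the number therefore tracks where the halogen sits rather than which halogen it is, and no measured evidence accounts for this.

Still open, on these data alone, is whether the lower number of compound 2 is specific to chlorine or would carry over to a methoxy group or an amine on the phenyl ring. Also open, as far as these compounds go, is how the hydroxyl group and a longer chain to the core would bear on this read-out.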